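The compounds below may be only part of what the source reports. "The series", "measured", "known", "first", "only" and "open" are said of these compounds alone.

Measured so far in an assay on cells for inhibition of cytochrome P450 11B2, mitochondrial (Homo sapiens), read by HTRF; a lower number here means a stronger inhibitor, a higher number a weaker inhibitor:
compound 1 `CC1(C)c2cc(Cl)ccc2C(=O)N1c1cccnc1`: 108 nM
compound 2 `CC1c2cc(Cl)ccc2C(=O)N1c1cccnc1`: 123 nM
compound 3 `CC(=O)N[C@@H]1CCCc2c1cncc2N1Cc2cc(Cl)ccc2C1=O`: 44 nM

Compound 1 gives the second highest of the three numbers; compound 2 lies within the scatter of it, while compound 3 stands beyond the scatter at a lower number. Compound 4 `CC1(C)c2cc(Cl)ccc2C(=O)N1c1cncc(CNS(C)(=O)=O)c1` differs from compound 1 by (methanesulfonamido)methyl in place of hydrogen on an aromatic carbon. Going by the values given here, the only single-point step measured, a 1.1-fold higher number from compound 1 to compound 2 (0.06 log units; within the scatter), alters a saturated ring carbon rather than the aromatic ring, so it gives no direct guide to this change. Among the compounds with values here, the lower number of compound 3, which carries a different substitution on that aromatic ring, is the only hint that a group on this ring need not raise the number. For compound 4 the step of a 1.3-fold lower number from compound 1 to compound 4 (0.10 log units; within the scatter) is therefore expected to stay within or only slightly beyond the scatter. Compound 4 is estimated at 85 nM, range 30 nM to 250 nM.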

Compound 4, half-maximal inhibitory concentration: 33 nM
The estimate for compound 4 lay 2.6-fold (0.41 log units) above the measured number, within the range that was stated.
By their numbers in this assay, from the lowest: compounds 4 and 3 (each within the scatter of the next); then compounds 1 and 2 (each within the scatter of the next).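

In this assay, (methanesulfonamido)methyl in place of hydrogen on this aromatic carbon, two atoms from the ring nitrogen, gives a 3.3-fold lower number from compound 1 to compound 4 (0.51 log units; beyond the scatter) and is the only single change shown that goes beyond the scatter. This position therefore accepts a chain of 6 heavy atoms with a lower number, not a higher one. No measurement at hand accounts for the step.

Still open, as far as these compounds go, is how an aminomethyl group, a carboxylic acid or a longer sulfonamide chain on this carbon would compare. Also open, from the compounds shown here alone, is whether the same group gives a like step on the core of compound 2.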